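The source may hold more compounds than are shown below. What is called first, only, known or untested is meant among the compounds shown, and "the series" means these compounds.

Working notes on the series, following a physicochemical assay for solubility; a higher number here means a more soluble compound, a lower number a less soluble compound.

Compound 1 `CNC(=O)c1cc(C(=O)NC2CC2)cn(Cc2cccc(OC)c2)c1=O` gives 79 ug/mL in this assay. Compound 3 `CNC(=O)c1cc(C(=O)NC2CCC2)cn(Cc2ccccc2)c1=O` gives 28 ug/mL, so compound 1 stands above it, beyond the scatter. Compound 2 `CNC(=O)c1cc(C(=O)NC2CCC2)cn(Cc2cccc(NC)c2)c1=O` reaches only the limit of the method at >= 155 ug/mL, a limit rather than a number (the limit of >= 155 ug/mL in this assay, at which 1 of the 3 values shown sits). Going by the values given here, the one measured step, an at least 5.5-fold lower number from compound 2 to compound 3 (0.74 log units; beyond the scatter), is the only guide to how a change on the benzyl ring moves this assay, and it points in neither direction for compound 4 `CNC(=O)c1cc(C(=O)NC2CC2)cn(Cc2cccc3cn[nH]c23)c1=O`, where the change is 1H-indazol-7-yl in place of 3-methoxyphenyl on a saturated chain carbon bound to an aromatic nitrogen. Among the compounds with values here, no step covering that change is measured, so the expectation for the step from compound 1 is a modest rise, a 1.4-fold higher number from compound 1 to compound 4 (0.14 log units; within the scatter), with wide uncertainty. Compound 4 is therefore estimated at 110 ug/mL, between 35 ug/mL and 320 ug/mL.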

Compound 4, solubility: >= 181 ug/mL
Compound 4 was reported as a limit (the forecaster's own chance of this, stated with the estimate: 25%); middle value at least 1.6-fold (0.21 log units) from the limit.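

Placing 1H-indazol-7-yl in place of 3-methoxyphenyl on a saturated chain carbon bound to an aromatic nitrogen gives an at least 2.2-fold higher number from compound 1 to compound 4 (0.36 log units; beyond the scatter) in this assay. This shows that exchanging the whole aromatic group at this place, and not only a substituent on the benzyl ring, can move the read-out beyond the scatter. The value of compound 4 is a limit and not a number: the limit of >= 181 ug/mL in this assay, at which 1 of the 4 values shown sits.

Open, going by these compounds, is how a pyridine ring or an indole at this place would read in this assay. Also open, on these data alone, is whether a benzyl ring carrying a carboxylic acid would give a number rather than a limit.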